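Sulfonamide series: dimethylamino in place of isopropyl on sulfur

A few compounds are considered here, and "the series" means these few. Any claim that something is new, unique, unknown or untested is made for them only; others in the source may bear on it.

Compound 2 `CC(C)S(=O)(=O)Nc1cccc2c1CCCC2c1c[nH]cn1` gives 2040 nM in an assay on isolated protein for binding affinity to Alpha-1D adrenergic receptor (Rattus norvegicus), read by radioligand binding; on this read-out higher numbers stand for weaker inhibition and lower numbers for stronger inhibition. Among the numbers measured it stands highest of the two. The nearest measured neighbour is compound 3 `O=S(=O)(Nc1cccc2c1CCCC2c1c[nH]cn1)c1ccc2ccccc2c1`, which in this assay gives 100 nM, a gap that lies beyond the usual scatter; no single-point change connects these two structures, so only the two values themselves can be compared. Compound 1 `CCCS(=O)(=O)Nc1cccc2c1CCCC2c1c[nH]cn1` is reported in this assay only as a limit, < 10000 nM, not as a number. This is the limit described by the limit of < 10000 nM in this assay, at which 1 of the 3 values shown sits. Because of that limit the step that the limit leaves unreadable from compound 1 to compound 2 cannot be read in size or direction.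

Compound 4 `CN(C)S(=O)(=O)Nc1cccc2c1CCCC2c1c[nH]cn1` is the next compound for this assay. It differs from compound 2 by dimethylamino in place of isopropyl on a sulfonyl sulfur. For the measured compounds named here, the only measured step at this position, from propyl to isopropyl, is unreadable, so no measured step bears on the new change with a known size. Without a readable precedent, no step beyond the scatter is assumed in either direction. The expected step is a 1.2-fold higher number from compound 2 to compound 4 (0.09 log units; within the scatter). Compound 4 is therefore estimated at 2500 nM in this assay, with a range from 700 nM to 9000 nM.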

Compound 4, inhibition constant: 1580 nM
For compound 4 the middle estimate is 1.6-fold (0.20 log units) above the measured one, and the stated range covers the measured number.
By their numbers in this assay, from the lowest: compound 3; then compounds 4 and 2 (each within the scatter of the next).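

At the sulfonyl sulfur, this assay now gives a first readable step: a 1.3-fold lower number from compound 2 to compound 4 (0.11 log units; within the scatter). Dimethylamino and isopropyl have the same heavy-atom count and differ by a nitrogen in place of a carbon, and this exchange leaves compound 2 and compound 4 within the scatter of each other, so the two cannot be ordered and this single change shows no measurable shift. Compound 1 is reported only as a limit, and the steps from it to compound 2 and to compound 4 cannot be read because of that limit: the limit of < 10000 nM in this assay, at which 1 of the 4 values shown sits.

For the compounds shown here, compound 3 gives 100 nM, and no single-place step links it to compound 2 or compound 4, so these notes do not establish what separates it from them. As far as these compounds go, it also remains open whether the flat result at this position would hold for a morpholine or a pyrrolidine on the sulfonyl sulfur, or for a diethylamino group, a longer version of the dimethylamino group that enters here.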